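A few compounds are considered here, and "the series" means these few. Any claim that something is new, unique, unknown or untested is made for them only; others in the source may bear on it.

Measured so far:
- compound 1, `CC1(C)N(O)C(c2ccc(OCC(=O)NCCCC[C@H](N)C(=O)O)cc2)=[N+]([O-])C1(C)C` — 29900 nM
- compound 2, `CC(C)(C)OC(=O)N[C@@H](CCCCNC(=O)COc1ccc(C2=[N+]([O-])C(C)(C)C(C)(C)N2O)cc1)C(=O)O` — 29300 nM

In a functional assay on PC-12 cells (Rattus norvegicus) for inhibition, read by MTT assay (a lower number here means that less compound is needed, a higher number that more compound is needed for the effect), compound 2 gives 29300 nM, and compound 1 gives 29900 nM; the two numbers are within the scatter of each other, so neither can be placed ahead of the other. Among the compounds with values here, the one measured step, a 1.0-fold lower number from compound 1 to compound 2 (0.01 log units; within the scatter), concerns a change on an amine nitrogen and left the number unchanged within the scatter.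

Compound 3, `C[C@H](NC(=O)[C@@H]1CCCN1)C(=O)N[C@@H](CCCCNC(=O)COc1ccc(C2=[N+]([O-])C(C)(C)C(C)(C)N2O)cc1)C(=O)O`, has not yet been measured. It differs from compound 2 in one place: 1-(((pyrrolidin-2-yl)carbonyl)amino)ethyl in place of tert-butoxy on a carbonyl carbon. Within the data shown here, this is a change at the same end of the molecule that the measured step altered, but it is a larger replacement, and no measured pair shows this exact exchange.

Among the measured compounds shown here, the only step that bears on it is from compound 1 to compound 2, which did nothing beyond the scatter. On that basis the expectation for compound 3 in this assay is a step of a 1.0-fold lower number from compound 2 to compound 3 (0.00 log units; within the scatter), that is, no change beyond the scatter. Compound 3 is therefore estimated at 29000 nM, with a range from 10000 nM to 90000 nM.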

Compound 3, half-maximal effective concentration: 28800 nM
For compound 3 the middle estimate is 1.0-fold (0.00 log units) above the measured one; measured number inside the range.
By their numbers in this assay, from the lowest: compounds 3, 2 and 1 (each within the scatter of the next).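

In this assay, the exchange of tert-butoxy for 1-(((pyrrolidin-2-yl)carbonyl)amino)ethyl on a carbonyl carbon gives a 1.0-fold lower number from compound 2 to compound 3 (0.01 log units; within the scatter). The entering group has 10 heavy atoms against 5 and brings a five-membered non-aromatic ring and 2 defined stereocentres, yet this much larger change leaves the number within the scatter. Read against the free amine, (1-(((pyrrolidin-2-yl)carbonyl)amino)ethyl)carbonyl on the amine nitrogen gives a 1.0-fold lower number from compound 1 to compound 3 (0.02 log units; within the scatter), so across these three compounds neither substituent on that nitrogen separates from the unsubstituted amine, and nothing available accounts for this flat result.

All three compounds carry the same carboxylic acid and the same chain to the shared core, so these comparisons say nothing about what those parts contribute. As far as these compounds go, it remains open whether a methyl ester in place of the carboxylic acid, or a shorter chain, would move the number beyond the scatter in this assay, and whether any group on the amine nitrogen can do so.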